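Methoxy in place of chloro on compound 2

The source may report more compounds than this note shows. Statements on the series, on what has been measured and on what is new or still open speak of the compounds shown alone.

In a functional assay on OVCAR-3 cells (Homo sapiens) for inhibition, read by sulforhodamine B assay, with a stated time of 48 h (a higher number here means a weaker inhibitor of growth, a lower number a stronger inhibitor of growth), compound 1 `CCOC(=O)c1nn(-c2ccc(Cl)cc2)c(-c2ccc(Cl)cc2)c1CNC(C)(C)C` gives 21600 nM; > 519000 nM (2 entries). The entry of compound 1 that carries a sign is a limit of the assay, not a number. Within the data shown here, compound 2 `CC(C)(C)NCc1c(C(=O)O)nn(-c2ccc(Cl)cc2)c1-c1ccc(Cl)cc1` gives 84900 nM, the only single number so far. Compound 3 `COc1ccc(-c2c(CNC(C)(C)C)c(C(=O)O)nn2-c2ccc(Cl)cc2)cc1` differs from compound 2 by methoxy in place of chloro on an aromatic carbon. Among the measured compounds shown here, no measured step in this assay covers this change, so no shift beyond the usual scatter is expected, in either direction. The estimated step of a 1.1-fold lower number from compound 2 to compound 3 (0.03 log units; within the scatter) is small. For compound 3 the expected value is 80000 nM, with an estimated range of 30000 nM to 200000 nM.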

Compound 3, concentration for 50% growth inhibition: 121000 nM
For compound 3 the middle estimate is 1.5-fold (0.18 log units) below the measured one; measured number inside the range.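

In this assay, the change from 4-chlorophenyl to 4-methoxyphenyl gives a 1.4-fold higher number from compound 2 to compound 3 (0.15 log units; within the scatter). Among these compounds, this is the first reading at this position, and it shows that methoxy can stand in place of chloro, para to a large group, with no shift beyond the scatter. Compound 1 carries a limit of the assay, not a number, among its entries, so weak readings in this series need caution: the several entries of compound 1 in this assay, 21600 nM; > 519000 nM (2 entries)

The compounds shown leave open whether an amine or a nitrile at this position would shift the number beyond the scatter. Also open, going by these compounds, is what methoxy would do on the other 4-chlorophenyl.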